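Ester capping of the chain acid in a bicyclic lactone series

The compounds below may be only part of what the source reports. "The series", "measured", "known", "first", "only" and "open" are said of these compounds alone.

Measured so far:
compound 1 `C[C@H]1N=C2C[C@H]3C[C@H](C3(C)C)[C@@]2(C)OC1=O` — 38000 nM
compound 2 `CC1(C)[C@@H]2CC3=N[C@@H](CCC(=O)O)C(=O)O[C@@]3(C)[C@H]1C2` — 38000 nM
compound 3 `CC1(C)[C@H]2CC3=N[C@H](CCC(=O)O)C(=O)O[C@]3(C)[C@@H]1C2` — 34000 nM

In a functional assay on MCF7 cells (Homo sapiens) for antiproliferative activity, read by sulforhodamine B assay, with a stated time of 48 h (a higher number here means a weaker inhibitor, a lower number a stronger inhibitor), compound 1 gives 38000 nM, compound 2 gives 38000 nM and compound 3 gives 34000 nM. Compound 3 carries the lowest of the three numbers, but its nearest neighbour compound 1 and its furthest neighbour compound 2 both sit within the scatter of it, so no order among the three can be read from these numbers.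

Two measured steps lead to compound 3. The first, a 1.1-fold lower number from compound 1 to compound 3 (0.05 log units; within the scatter), adds the chain acid to the shared core of compound 1 without moving the number beyond the scatter. The second, a 1.1-fold lower number from compound 2 to compound 3 (0.05 log units; within the scatter), rests on the fact that compounds 2 and 3 differ only in the configuration as drawn and is equally flat.

Compound 4 `CC(C)(C)OC(=O)CC[C@H]1N=C2C[C@H]3C[C@H](C3(C)C)[C@@]2(C)OC1=O` is the next step from compound 3: tert-butyl in place of hydrogen on an oxygen next to a carbonyl group. Going by the values given here, no measured step touches the oxygen of the chain acid, so the only guide is that neither adding the acid chain nor inverting every stereocentre changed this assay. On that basis compound 4 is expected to stay close to compound 3, with a step of a 1.0-fold higher number from compound 3 to compound 4 (0.01 log units; within the scatter) that is not beyond the scatter. The estimate for compound 4 in this assay is 35000 nM, expected to fall between 12000 nM and 100000 nM.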

Compound 4, half-maximal inhibitory concentration: 54000 nM
Estimate against measurement, compound 4: 1.5-fold (0.19 log units) below; the range from low to high includes it.
By their numbers in this assay, from the lowest: compounds 3, 1, 2 and 4 (each within the scatter of the next).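

In this assay, carboxy to tert-butoxycarbonyl is the only change shown on an oxygen next to a carbonyl group, and it gives a 1.6-fold higher number from compound 3 to compound 4 (0.20 log units; within the scatter), so this position does not yet separate the free acid from its tert-butyl ester. The full (tert-butoxycarbonyl)methyl group, set against hydrogen on a saturated chain carbon bound to a saturated ring carbon, gives a 1.4-fold higher number from compound 1 to compound 4 (0.15 log units; within the scatter), so neither the carboxymethyl group nor its capped form is resolved from the hydrogen of compound 1 in this series. Nothing on hand explains why the numbers stay level across this change.

The compounds shown leave open whether a smaller ester such as methyl, an amide or a longer chain at this place would move the number in this assay beyond the scatter. Also open, on these data alone, is whether the tert-butyl ester of the mirror-image form, the configuration of compound 2, would read as level as the free acids of compound 2 and compound 3 do.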